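Working notes: from compound 2 to compound 3

The source may report more compounds than this note shows. Statements on the series, on what has been measured and on what is new or still open speak of the compounds shown alone.

Measured in an ADME assay on a cell-free system (plasma, Homo sapiens) for metabolic stability, read by LC-MS; a lower number here means that the compound disappears faster, a higher number that the compound lasts longer:
- compound 1 `NCc1ccc(C(=O)Nc2ccncc2F)cc1-c1cccc(C(=O)OCC2CCCCO2)c1` gives 0.117 h
- compound 2 `CCCOC(=O)c1cccc(-c2cc(C(=O)Nc3ccncc3F)ccc2CN)c1` gives 0.317 h

In this assay, for the measured compounds named here, compound 2 holds the higher of the two numbers, at 0.317 h, and compound 1 is its only neighbour. The next structure is compound 3 `NCc1ccc(C(=O)Nc2ccncc2F)cc1-c1cccc(C(=O)OCC2CCCC2)c1`. The change from compound 2 is cyclopentyl in place of ethyl on a saturated chain carbon bound to an oxygen next to a carbonyl group, which can also be read as propoxycarbonyl to cyclopentylmethoxycarbonyl.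

Going by the values given here, only one measured step bears on this place: a 2.7-fold higher number from compound 1 to compound 2 (0.43 log units; beyond the scatter). It is modest, and it replaces a ring-bearing group, oxan-2-yl, with ethyl. Compound 3 reverses that kind of change in part, since ethyl leaves and a ring enters, but its ring is a five-membered one of carbon only. Among the compounds with values here, one step is thin evidence, and no measured compound carries cyclopentyl. A small move towards a lower number is therefore expected, possibly not beyond the scatter, and the value of compound 1 at 0.117 h serves as a rough lower guide. The expected step is a 1.6-fold lower number from compound 2 to compound 3 (0.20 log units; within the scatter). For compound 3 the estimate is 0.2 h, with an expected range from 0.09 h to 0.45 h.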

Compound 3, half-life: 0.283 h
Beside the measured number, compound 3's estimate is 1.4-fold (0.15 log units) below it; measured number inside the range.
By their numbers in this assay, from the lowest: compound 1; then compounds 3 and 2 (each within the scatter of the next).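

Replacing ethyl with cyclopentyl on a saturated chain carbon bound to an oxygen next to a carbonyl group leaves the half-life in this assay without a readable change (a 1.1-fold lower number from compound 2 to compound 3 (0.05 log units; within the scatter)), so this position accepts a five-membered non-aromatic ring of carbon only in place of the open chain. Exchanging oxan-2-yl for cyclopentyl at the same place gives a clear difference (a 2.4-fold higher number from compound 1 to compound 3 (0.38 log units; beyond the scatter)), which shows that a ring as such does not mark the lower end of this short series: of the three groups, only oxan-2-yl stands apart. Nothing available speaks to what lies behind these numbers.

For the compounds shown here, with only three groups at this position, cyclohexyl would be the informative next comparison, since it would separate ring size from the ring oxygen of oxan-2-yl. Also open is how this assay responds to a longer chain, or to a chain carrying an amine or a carboxylic acid, and whether an amide in place of the ester would keep the same order among these groups.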